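Working notes on replacing dimethylamino in the series

The source may hold more compounds than are shown below. What is called first, only, known or untested is meant among the compounds shown, and "the series" means these compounds.

Three compounds on a shared core have readings so far in an ADME assay on L6 cells (Rattus norvegicus) for cytotoxicity, read by resazurin assay, with a stated time of 72 h (a lower number here means a stronger inhibitor, a higher number a weaker inhibitor), for comparison. Compound 1 (`CC(C)c1ccc(C(=O)NC(=O)c2ccccc2O)cc1`) gives 19 ug/mL in this read-out. Compound 3 (`CN(C)c1ccc(C(=O)NC(=O)c2ccccc2O)cc1`) gives 54 ug/mL as the higher of the two actual numbers, and compound 1 is its nearest neighbour. Compound 2 (`CS(=O)(=O)c1ccc(C(=O)NC(=O)c2ccccc2O)cc1`) reads > 100 ug/mL as a limit of the assay and not a number.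

The next entry is compound 4 (`COC(=O)CCC(=O)Nc1ccc(C(=O)NC(=O)c2ccccc2O)cc1`). The change is ((2-(methoxycarbonyl)ethyl)carbonyl)amino in place of dimethylamino on an aromatic carbon and puts ((2-(methoxycarbonyl)ethyl)carbonyl)amino in place of dimethylamino on an aromatic carbon.

Within the data shown here, three measured steps concern this same place. They are a 2.8-fold higher number from compound 1 to compound 3 (0.45 log units; beyond the scatter) and an at least 5.2-fold higher number from compound 1 to compound 2 (0.72 log units; beyond the scatter) along with an at least 1.8-fold lower number from compound 2 to compound 3 (0.26 log units; that floor lies within the scatter) as the third. None of them carries the incoming chain, so they show only the span seen so far at this place. With compound 3 at 54 ug/mL in the upper part of that span, no step beyond the scatter is expected, with a slight lean towards a higher number. The expected step is a 1.1-fold higher number from compound 3 to compound 4 (0.05 log units; within the scatter) as an estimate for now. For compound 4 the estimated value is 60 ug/mL with an expected range from 25 ug/mL to 120 ug/mL in this assay once measured.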

Compound 4, half-maximal inhibitory concentration: > 50 ug/mL
Compound 4 was reported as a limit; the forecaster's own chance of this, stated with the estimate: 35%; the middle value lies beyond the limit too.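

In this assay compound 4 is reported only as a limit and not as a number: the limit of > 50 ug/mL in this assay, at which 1 of the 4 values shown sits.

Among these compounds, the one readable step is an at least 2.6-fold higher number from compound 1 to compound 4 (0.42 log units; beyond the scatter), which makes ((2-(methoxycarbonyl)ethyl)carbonyl)amino the third group at this place, after dimethylamino and methylsulfonyl, whose step from isopropyl lies beyond the scatter and points to a higher number. The steps to compound 4 from compound 2 and from compound 3 cannot be read, so the new entry extends the set of groups at this place to an open chain with a hydrogen-bond donor, which dimethylamino lacks, but does not rank that chain against dimethylamino or methylsulfonyl.

The compounds shown leave open whether the step from isopropyl follows the methoxycarbonyl end of the chain, the carbonylamino part or the chain length, and where compound 4 would fall relative to compound 3 if it had a number. A plain amine at this place, a shorter acetylamino group, or a carboxylic acid in place of the methyl ester would each separate one of these parts from the others.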